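Methyl added to the side chain: expected cytotoxicity of compound 4

The source may hold more compounds than are shown below. What is called first, only, known or untested is meant among the compounds shown, and "the series" means these compounds.

Compound 1 `CCN(C)c1nc(Cc2c(F)cccc2F)cc(=O)[nH]1` and compound 2 `CC(C)N(C)c1nc(Cc2c(F)cccc2F)cc(=O)[nH]1` share one core; compound 3 `Cc1c(C(C)c2c(F)cccc2F)nc(N(C)C)[nH]c1=O` and compound 4 `CCC(c1nc(N(C)C)[nH]c(=O)c1C)c1c(F)cccc1F` share another, and the difference between the two cores is not broken down here. In an ADME assay on MT4 cells (Homo sapiens) for cytotoxicity, read by MTT assay, with a stated time of 4 days (on this read-out higher numbers stand for lower toxicity in this test and lower numbers for higher toxicity in this test), compound 1 gives a limit of > 89000 nM, not a number. In this assay compound 2 gives 85000 nM. The step of an at least 1.0-fold lower number from compound 1 to compound 2 (0.01 log units; that floor lies within the scatter) comes from methyl in place of hydrogen on a saturated chain carbon bound to a nitrogen on an aromatic ring and a saturated chain carbon. In this assay compound 3 gives a limit of > 17000 nM, not a number. The change to compound 4, (methyl in place of hydrogen on a saturated chain carbon, two bonds along the chain from two aromatic carbons), is the same kind of change, though its place differs: there the carbon is bound to a nitrogen on an aromatic ring and a saturated chain carbon, here it lies two bonds along the chain from two aromatic carbons. Resting on the step of an at least 1.0-fold lower number from compound 1 to compound 2 (0.01 log units; that floor lies within the scatter) and on compound 3 sitting at the limit of > 17000 nM in this assay, at which 1 of the 3 values shown sits, compound 4 is expected to show about a step that the limit leaves unreadable from compound 3 to compound 4. Compound 4 is therefore estimated at 20000 nM in this assay, likely again only a limit.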

Compound 4, half-maximal cytotoxic concentration: > 81000 nM
Compound 4: only a limit was reported (the forecaster's own chance of this, stated with the estimate: 70%); middle value at least 4.0-fold (0.60 log units) away from the limit.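

In this assay, among these compounds, compound 3 and compound 4 are each reported only as a limit, not a number, so no step between them can be read. The compounds shown leave open whether this added methyl changes cytotoxicity at all.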